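The source may report more compounds than this note shows. Statements on the series, on what has been measured and on what is new or still open speak of the compounds shown alone.

Measured so far in a functional assay on DLD-1 cells (Homo sapiens) for antiproliferative activity, read by CellTiter-Glo, with a stated time of 72 h; on this read-out higher numbers stand for weaker inhibition and lower numbers for stronger inhibition:
- compound 1 `Cc1ccc(-c2cccc(S(=O)(=O)N3CCC(N4CCC(C)CC4)CC3)c2)cc1`: 11 nM
- compound 2 `CC1CCN(C2CCN(S(=O)(=O)c3nccn3C)CC2)CC1`: > 5000 nM, a limit of the assay
- compound 3 `Cc1cc(C)c(S(=O)(=O)N2CCC(N3CCC(C)OC3)CC2)c(C)c1`: 92 nM

Compound 1 holds the lowest of the two numbers in this assay; compound 3 sits at a higher number, beyond the scatter. Compound 2 reaches only a limit of the assay, (the limit of > 5000 nM in this assay, at which 1 of the 3 values shown sits).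

Compound 4 `CC1CCN(C2CCN(S(=O)(=O)c3cccc(-c4ccccc4)c3)CC2)CC1` differs from compound 1 by hydrogen in place of methyl on an aromatic carbon. Among the compounds with values here, no measured pair shows this change, so its size is not known from the series. A small rise in the number is expected for compound 4, close to the edge of the scatter. Compound 4 is expected at 25 nM, with a range of 8 nM to 80 nM. The step of a 2.3-fold higher number from compound 1 to compound 4 (0.36 log units; beyond the scatter) is the expected outcome of the change.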

Compound 4, half-maximal inhibitory concentration: 2 nM
The estimate for compound 4 lay 13-fold (1.10 log units) above the measured number; measured number below the stated range.
By their numbers in this assay, from the lowest: compound 4; then compound 1; then compound 3. At a limit, above all of these: compound 2.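

In this assay, the change from 4-methylphenyl to phenyl gives a 5.5-fold lower number from compound 1 to compound 4 (0.74 log units; beyond the scatter), so the methyl is not needed at this position and hydrogen serves better here. Within the data shown here, this is the first pair that differs in one place, and it is the only reading of this position. Nothing measured on these compounds gives a cause for the step.

Open, from the compounds shown here alone, is whether a fluorine, a chlorine, a methoxy group or a nitrile at this place would hold the number of compound 4. Also open, going by these compounds, is whether the same change would give a similar step on another core.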